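This account rests on a few compounds, and the source may have more. Where it says the series, first, only, none or still open, it means among the compounds named here.

Of the compounds shown here, three have so far been tested in a functional assay on MCF7 cells (Homo sapiens) for cytotoxicity, read by sulforhodamine B assay, with a stated time of 72 h; a higher number here means a weaker inhibitor, a lower number a stronger inhibitor. Compound 1 `O=C(Nc1ccccc1)Nc1ccc(Oc2ncnc3c2cnn3-c2ccccc2)cc1` gives only a limit of the assay in this assay, > 100000 nM, rather than a number. Compound 2 `O=C(Nc1ccccc1)Nc1ccc(Oc2ncnc3c2cnn3-c2ccc(Cl)cc2)cc1` gives 82500 nM in this assay. The change from compound 1 to compound 2 is chloro in place of hydrogen on an aromatic carbon, and it produced an at least 1.2-fold lower number from compound 1 to compound 2 (0.08 log units; that floor lies within the scatter), a step that rests on one side on a limit (the limit of > 100000 nM in this assay, at which 1 of the 3 values shown sits). Compound 3 `O=c1sc2cc(Nc3ncnc4c3cnn4-c3ccccc3)ccc2n1Cc1ccc(Cl)cc1Cl` is built on a different core, and how its core differs from that of compound 1 is not broken down here; in this assay compound 3 gives 44000 nM. Compound 4 `O=c1sc2cc(Nc3ncnc4c3cnn4-c3ccc(Cl)cc3)ccc2n1Cc1ccc(Cl)cc1Cl` has not yet been measured. It differs from compound 3 by chloro in place of hydrogen on an aromatic carbon, and since the place is described in the same words for both pairs, this is the same change that turned compound 1 into compound 2. For compound 4 a somewhat lower number is expected in this assay, a step of about a 1.5-fold lower number from compound 3 to compound 4 (0.17 log units; within the scatter), because an at least 1.2-fold lower number from compound 1 to compound 2 (0.08 log units; that floor lies within the scatter) points the same way while resting partly on a limit. The estimate for compound 4 is 30000 nM, with a likely range from 10000 nM to 90000 nM.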

Compound 4, half-maximal inhibitory concentration: > 100000 nM
Compound 4: no number, only a limit (the forecaster's own chance of this, stated with the estimate: 10%); middle value at least 3.3-fold (0.52 log units) from the limit.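

On the core of compound 3, phenyl to 4-chlorophenyl gives an at least 2.2-fold higher number from compound 3 to compound 4 (0.35 log units; beyond the scatter) in this assay, so the change does not carry over unaltered from the core of compound 1, and the two steps differ: the same change on two cores in this assay, an at least 1.2-fold lower number (0.08 log units; that floor lies within the scatter) from compound 1 to compound 2 and an at least 2.2-fold higher number (0.35 log units; beyond the scatter) from compound 3 to compound 4, at least 2.7-fold (0.44 log units) apart, beyond the scatter of two such steps. Compound 1 and compound 4 each give only a limit of the assay, not a number, so both steps are floors rather than full sizes: the limit of > 100000 nM in this assay, at which 2 of the 4 values shown sit. The result shows that the outcome of this change depended on the core in these two pairs, but it does not show why, how large either step really is, or whether two pairs make a rule for the series.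

The compounds shown leave open what other groups would do in the same place on either core, such as fluoro, methoxy, an amine or a carboxylic acid. From the compounds shown here alone, it also remains open whether chloro on another carbon of that ring would split the two cores in the same way.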